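Fluoro on the other phenyl: compound 4

A few compounds are considered here, and "the series" means these few. Any claim that something is new, unique, unknown or untested is made for them only; others in the source may bear on it.

For the measured compounds named here, compound 1 `O=C(Nc1nc2ccccc2s1)c1cn(-c2ccccc2)nc1-c1ccccc1` gives 8960 nM in a functional assay on U-87MG ATCC cells for cytotoxicity against U-87 MG (Homo sapiens), read by MTT assay, with a stated time of 72 h (a lower number here means a stronger inhibitor, a higher number a weaker inhibitor), the highest of the three numbers so far. Compound 2 `O=C(Nc1nc2ccc(F)cc2s1)c1cn(-c2ccccc2)nc1-c1ccccc1` gives 5570 nM and compound 3 `O=C(Nc1nc2ccc(Cl)cc2s1)c1cn(-c2ccccc2)nc1-c1ccccc1` gives 4980 nM. The steps of a 1.6-fold lower number from compound 1 to compound 2 (0.21 log units; within the scatter), a 1.8-fold lower number from compound 1 to compound 3 (0.26 log units; within the scatter) and a 1.1-fold lower number from compound 2 to compound 3 (0.05 log units; within the scatter) all stay within the scatter. Compound 4 `O=C(Nc1nc2ccccc2s1)c1cn(-c2ccccc2)nc1-c1ccc(F)cc1` differs from compound 1 by fluoro in place of hydrogen on an aromatic carbon, para to a large group; one bond further out this reads phenyl to 4-fluorophenyl. Going by the values given here, no measured step puts fluoro on this ring; the nearest comparison, fluoro on another aromatic carbon, moved within the scatter. Compound 4 is therefore expected close to compound 1, with a 1.2-fold lower number from compound 1 to compound 4 (0.08 log units; within the scatter) not beyond the scatter. The estimate for compound 4 is 7500 nM, range 3000 nM to 20000 nM.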

Compound 4, half-maximal inhibitory concentration: 10700 nM
Compound 4: middle estimate off by 1.4-fold (0.15 log units), on the low side, and the stated range covers the measured number.
By their numbers in this assay, from the lowest: compounds 3, 2, 1 and 4 (each within the scatter of the next, the first and the last beyond it).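

In this assay, fluoro on this phenyl gives a 1.2-fold higher number from compound 1 to compound 4 (0.08 log units; within the scatter), so the 4-fluorophenyl is tolerated, with the step inside the scatter. Together with the earlier fluoro step, this shows the same replacement of hydrogen staying within the scatter on a second aromatic ring of the core of compound 1. No supporting evidence bears on this result.

Open, on these data alone, is whether a different kind of group at this position, such as an amine, a carboxylic acid or a longer chain, gives a step beyond the scatter. As far as these compounds go, the response of the remaining phenyl to any such change also stays open.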